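The source may report more compounds than this note shows. Statements on the series, on what has been measured and on what is new or still open speak of the compounds shown alone.

Measured so far:
compound 1 `O=C(CN(c1nc(Cl)nc2[nH]cnc12)C1CC1)N[C@@H](CO)C(=O)O` – 43.9%
compound 2 `O=C(O)CNC(=O)CN(c1nc(Cl)nc2[nH]cnc12)C1CC1` – 32.3%

In a functional assay on the whole organism (Tail, strain ICR) with Mus musculus as the target, in the tail flick test, with a stated time of 90 min, at a dose of 25 umol/kg by the oral route (a higher number here means a stronger effect of the compound at the dose given, a lower number a weaker effect), compound 1 gives 43.9%, and compound 2 gives 32.3%. Among the compounds with values here, of the two numbers compound 2 stands lowest; its nearest neighbour is compound 1, and the single measured step, a number 11.6 percentage points lower from compound 1 to compound 2 (beyond the scatter), is beyond the scatter but modest.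

Compound 3 `NCCCC[C@H](NC(=O)CN(c1nc(Cl)nc2[nH]cnc12)C1CC1)C(=O)O` has not yet been measured. It differs from compound 2 by 4-aminobutyl in place of hydrogen on a saturated chain carbon bound to an amide-type nitrogen and a carbonyl carbon. Within the data shown here, the one step that bears on this change is a number 11.6 percentage points lower from compound 1 to compound 2 (beyond the scatter), in which a substituent at the same place was removed and the activity fell. Read in reverse, putting a substituent back onto that carbon might restore some activity, but 4-aminobutyl is not hydroxymethyl, and nothing measured shows what a chain of this kind does there. The step of a number 5.7 percentage points higher from compound 2 to compound 3 (within the scatter) is therefore expected to be small, most likely upward but possibly within the scatter. For compound 3 the estimated activity in this assay is 38%, within a range of 15% to 60%.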

Compound 3, a percentage reported as activity, at one dose (the size of the read-out at that dose, not a potency): 28.8%
Compound 3: middle estimate off by 9.2 percentage points, on the high side, and the stated range covers the measured number.
By their numbers in this assay, from the lowest: compounds 3 and 2 (each within the scatter of the next); then compound 1.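

In this assay, the step (a number 3.5 percentage points lower from compound 2 to compound 3 (within the scatter)) shows that 4-aminobutyl in place of hydrogen on a saturated chain carbon bound to an amide-type nitrogen and a carbonyl carbon does not separate compound 3 from compound 2, so the presence of a substituent at this carbon does not in itself bring the read-out back to the level of compound 1. The other comparison, 3-aminopropyl in place of hydroxy (a number 15.1 percentage points lower from compound 1 to compound 3 (beyond the scatter)), is beyond the scatter, and with the earlier step (a number 11.6 percentage points lower from compound 1 to compound 2 (beyond the scatter)) it leaves compound 1, with its hydroxymethyl, as the most active of the three at this one dose, while the other two cannot be told apart. Nothing given here explains why the hydroxymethyl and 4-aminobutyl compounds differ.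

The compounds shown leave open whether the hydroxy group itself matters or whether other small groups at this carbon would serve as well, such as a methyl, a 1-hydroxyethyl or a carboxylic acid on a short chain. They also leave open whether a shorter amine chain, such as aminomethyl, would read differently from 4-aminobutyl.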